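This account rests on a few compounds, and the source may have more. Where it says the series, first, only, none or still open, it means among the compounds named here.

Compound 1, with the structure `CC(=O)OCCOn1cnc2c(Cl)nc(N)nc21`, is one of a small set of closely related molecules tested for their ability to block a human target in a functional assay (Homo sapiens) for inhibition; a higher number here means a weaker inhibitor, a lower number a stronger inhibitor. In this assay compound 1 gives only a limit, > 500000 nM, and not a measured number. Compound 2, with the structure `CC(=O)OCCOn1cnc2c(Cl)nc(I)nc21`, likewise gives only a limit, > 500000 nM. For the measured compounds named here, the only measured step between two compounds that differ in one place, iodo in place of amino on an aromatic carbon, is therefore the step that the two limits leave unreadable from compound 1 to compound 2, whose size the two limits leave unreadable; this follows from the limit of > 500000 nM in this assay, at which 2 of the 3 values shown sit. Going by the values given here, the third compound, compound 3, with the structure `CC(=O)OC(C)n1cnc2c(S)nc(N)nc21`, is the only one with a measured number: in this assay compound 3 gives 25000 nM.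

The compound still to be measured is compound 4, with the structure `CC(=O)OCCOn1cnc2c(S)nc(N)nc21`. It differs from compound 1 by sulfanyl in place of chloro on an aromatic carbon, in words sulfanyl in place of chloro on an aromatic carbon. Among the compounds with values here, no measured step covers this exchange, so the expectation rests on the one measured number: compound 3 also carries a sulfanyl group and an amino group, though its chain attached to the ring nitrogen is different, and its value of 25000 nM is the nearest anchor. Compound 4 is expected to reach a measurable number, with an estimated step of an at least 8.3-fold lower number from compound 1 to compound 4 (0.92 log units; beyond the scatter) from compound 1. Compound 4 is therefore estimated at 60000 nM, in a range from 12000 nM to 400000 nM, and the measured value now follows.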

Compound 4, half-maximal inhibitory concentration: > 500000 nM
Compound 4 was reported as a limit; the forecaster's own chance of this, stated with the estimate: 30%; at least 8.3-fold (0.92 log units) between middle value and limit.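

Compound 1 and compound 4 both give only a limit in this assay, so no size can be read for the exchange of chloro for sulfanyl between them: the limit of > 500000 nM in this assay, at which 3 of the 4 values shown sit.

The compounds shown leave open whether this exchange changes inhibition at all, and how the chain on the ring nitrogen bears on it.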